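Ethoxy in place of ethylsulfanyl: an expected stability

The source may hold more compounds than are shown below. What is called first, only, known or untested is meant among the compounds shown, and "the series" means these compounds.

Of the compounds shown here, three have been measured in an ADME assay on microsomes from liver (Rattus norvegicus) for metabolic stability, with a stated time of 10 min; on this read-out higher numbers stand for a more stable compound and lower numbers for a less stable compound. Compound 2 (`CCSc1nn2cc(-c3cc4ccccc4o3)nc2s1`) gives 35%, the middle of the three numbers. Compound 1 (`COc1nn2cc(-c3cc4ccc(OC)c(OC)c4o3)nc2s1`) gives 3% and compound 3 (`COc1nn2cc(-c3cc4ccc(OCc5ccccc5)cc4o3)nc2s1`) gives 68%, both gaps being beyond the scatter.

The next compound, compound 4 (`CCOc1nn2cc(-c3cc4ccccc4o3)nc2s1`), departs from compound 2 in one place: ethoxy in place of ethylsulfanyl on an aromatic carbon. This puts ethoxy in place of ethylsulfanyl on an aromatic carbon. Going by the values given here, no measured pair isolates this exchange. Compound 1 and compound 3 each carry a methoxy group at that place, but they also differ elsewhere, and compound 1 gives 3% while compound 3 gives 68%, which points in no single direction. The expected step, a number 3 percentage points higher from compound 2 to compound 4 (within the scatter), is therefore not expected to go beyond the scatter in this assay. For compound 4 the estimate is 38%, with an expected range of 14% to 65%.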

Compound 4, percent of the compound remaining: 37%
Compound 4: the middle estimate sits 1 percentage points above what was measured; measured number inside the range.
By their numbers in this assay, from the lowest: compound 1; then compounds 2 and 4 (each within the scatter of the next); then compound 3.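

Going by these compounds alone, the pair gives the first direct reading of this exchange: in this assay, ethoxy in place of ethylsulfanyl gives a number 2 percentage points higher from compound 2 to compound 4 (within the scatter). On this aromatic carbon, next to the ring nitrogen and next to the ring sulfur, the two groups therefore cannot be told apart on this read-out when the rest of the structure is held constant. No measurement shown here bears on the reason for this outcome.

As far as these compounds go, this one pair shares a single core, so it remains open whether the exchange would read the same way on the substituted cores of compound 1 and compound 3. From the compounds shown here alone, it also remains open how an amine or a longer chain such as butoxy would read at this place.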